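This account rests on a few compounds, and the source may have more. Where it says the series, first, only, none or still open, it means among the compounds named here.

Compound 1, `Cc1cc(C)cc(C(=O)N(CC(=O)NCc2ccccc2)Cc2ccc(C(=O)Nc3cc(-c4ccccc4)ccc3N)cc2)c1`, was tested in an assay on Sf9 cells for inhibition of protein deacetylase HDAC6 (Homo sapiens), read by fluorescence, with a stated time of 90 min; on this read-out lower numbers stand for stronger inhibition and higher numbers for weaker inhibition. In this assay compound 1 gives > 10000 nM, which is a limit of the assay rather than a number. Its close relative compound 2, `CN(C)c1ccc(C(=O)N(CC(=O)NCc2ccccc2)Cc2ccc(C(=O)Nc3cc(-c4ccccc4)ccc3N)cc2)cc1`, differs only at the carbonyl carbon, carrying a 4-(dimethylamino)phenyl in place of the 3,5-dimethylphenyl; in this assay compound 2 gives > 10000 nM, again a limit. The step that the two limits leave unreadable from compound 1 to compound 2 therefore cannot be read. Compound 3, `CN(C)c1ccc(C(=O)N(CCCCCC(=O)Nc2cc(F)ccc2N)CC(=O)NCc2ccccc2)cc1`, belongs to the same series; in this assay compound 3 gives > 10000 nM, also a limit. Compound 1 thus stands where every measured compound stands: at the limit, with no number that would rank it against the others. The new compound 4, `Cc1cc(C)cc(C(=O)N(CC(=O)NCc2ccccc2)Cc2ccc(C(=O)Nc3cc(F)ccc3N)cc2)c1`, changes compound 1 on an aromatic carbon of the core: fluoro in place of phenyl on an aromatic carbon. Going by the values given here, no measured step covers this exact change, and the only step measured, from compound 1 to compound 2, is unreadable. Because (the limit of > 10000 nM in this assay, at which 3 of the 3 values shown sit), the expected step that the limit leaves unreadable from compound 1 to compound 4 is no step beyond the scatter, and compound 4 is expected most likely to return another limit. Compound 4 is estimated at 15000 nM, within a range from 4000 nM to 60000 nM.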

Compound 4, half-maximal inhibitory concentration: > 10000 nM
Compound 4 gave a limit, no number (the forecaster's own chance of this, stated with the estimate: 80%); the middle value does not contradict the limit.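

Compound 1 and compound 4 both return only a limit in this assay, so the swap of phenyl for fluoro cannot be read as a step of any size. The compounds shown leave open how strongly any of them inhibits, and which change, if any, would give a real number, since all share one result: the limit of > 10000 nM in this assay, at which 4 of the 4 values shown sit.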